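Aryl thioether swap carried onto the saturated amide core

The source may hold more compounds than are shown below. What is called first, only, known or untested is meant among the compounds shown, and "the series" means these compounds.

Compound 1 `Nc1ccccc1NC(=O)/C=C/c1ccc(CSc2cccc(F)c2)cc1` and compound 3 `Cc1ccc(SCc2ccc(/C=C/C(=O)Nc3ccccc3N)cc2)cc1` share one core, while compound 2 `Nc1ccccc1NC(=O)c1ccc(CSc2cccc(F)c2)cc1` and compound 4 `Cc1ccc(SCc2ccc(C(=O)Nc3ccccc3N)cc2)cc1` share another; the difference between the two cores is not broken down here. In a functional assay on HeLa cells (Homo sapiens) for inhibition, read by CCK-8 assay, with a stated time of 72 h, tested at 2 uM (on this read-out higher numbers stand for more inhibition of growth at the one concentration tested and lower numbers for less inhibition of growth), compound 1 gives 2.25%, compound 3 gives 25.5% and compound 2 gives 22.5%. Between compound 1 and compound 3 the change is 4-methylphenyl in place of 3-fluorophenyl on a sulfur and it produced a number 23.3 percentage points higher from compound 1 to compound 3 (beyond the scatter). Compound 4 is reached from compound 2 by 4-methylphenyl in place of 3-fluorophenyl on a sulfur and the place is the same in both cases, so this is the same change. Compound 4 has not been measured. The expected step is a number 19.5 percentage points higher from compound 2 to compound 4 (beyond the scatter), set beside a number 23.3 percentage points higher from compound 1 to compound 3 (beyond the scatter). This expectation rests on a single measured pair and on compound 2 standing at 22.5%, so the range is kept wide. Compound 4 is accordingly estimated at 42%, between 22% and 62%.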

Compound 4, percent growth inhibition at one concentration: 33.8%
Estimate against measurement, compound 4: 8.2 percentage points above; low and high end bracket the measured number.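

In this assay, 4-methylphenyl in place of 3-fluorophenyl on a sulfur gives a number 11.3 percentage points higher from compound 2 to compound 4 (beyond the scatter) on the second core, so the change raises the number on both cores shown. The two steps do not differ beyond the scatter: the same change on two cores in this assay, a number 23.3 percentage points higher (beyond the scatter) from compound 1 to compound 3 and a number 11.3 percentage points higher (beyond the scatter) from compound 2 to compound 4, 12 percentage points apart, within the scatter of two such steps. This supports carrying the change between these two cores only, resting on one pair per core at a single concentration, and it does not show that the change would hold on any further core.

The compounds shown leave open whether the step follows the loss of the fluorine or the gain of the methyl. An unsubstituted phenyl or a 3-methylphenyl on the sulfur would separate the two.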